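Swapping a Pyrazole for a Benzamide in a Cytotoxicity Series

The compounds below may be only part of what the source reports. "The series", "measured", "known", "first", "only" and "open" are said of these compounds alone.

Compound 1 `CC(C)Cn1cc(-c2cc(Nc3ccc(OC(F)(F)F)cc3)ncn2)cn1` was tested in an ADME assay on BaF3 cells (Mus musculus) for cytotoxicity; a lower number here means that less compound is needed, a higher number that more compound is needed for the effect. In this assay compound 1 gives > 10000 nM, which is a limit of the assay rather than a measured number. Compound 2 `FC(F)(F)Oc1ccc(Nc2ncnc3nn(C4CCCCC4)cc23)cc1` likewise gives > 10000 nM, again a limit. Compound 3 `CCCn1ncc2c(Nc3ccc(OC(F)(F)F)cc3)ncnc21` gives 6600 nM. Compound 1 therefore stands at the limit of > 10000 nM in this assay, at which 2 of the 3 values shown sit, and only compound 3 offers a number, which sits close to that limit. No two of these compounds differ in just one place, so no measured step can be read from them.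

Compound 4 `NC(=O)c1ccc(-c2cc(Nc3ccc(OC(F)(F)F)cc3)ncn2)cc1` has not yet been measured. It differs from compound 1 by 4-carbamoylphenyl in place of 1-isobutyl-1H-pyrazol-4-yl on an aromatic carbon. With nothing measured around this change, no step beyond the usual scatter is expected. The expected step from compound 1 to compound 4 is a step that the limit leaves unreadable from compound 1 to compound 4, keeping compound 4 in the same region as compound 1. Compound 4 is estimated to give 12000 nM, within a range from 4000 nM to 40000 nM.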

Compound 4, half-maximal effective concentration: > 10000 nM
Compound 4: only a limit was reported (the forecaster's own chance of this, stated with the estimate: 70%); the middle value is on the limit's open side.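

Compound 1 and compound 4 both give only a limit of the assay, not a number, so no step between them can be read in this assay: the limit of > 10000 nM in this assay, at which 3 of the 4 values shown sit.

As far as these compounds go, how far either true value lies past that limit, and whether 4-carbamoylphenyl in place of 1-isobutyl-1H-pyrazol-4-yl changes it at all, stays open.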